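The source may hold more compounds than are shown below. What is called first, only, known or untested is meant among the compounds shown, and "the series" means these compounds.

The compounds measured so far, all in a functional assay, read by spectrophotometry, with a stated time of 30 min; on this read-out lower numbers stand for stronger inhibition and higher numbers for weaker inhibition:
compound 1 `Cc1ccc(-c2c3ccc4ccccc4c3nc3c2c(C)nc2c4ccccc4ccc32)cc1` gives 123 ug/mL;
compound 2 `Cc1nc2c3ccccc3ccc2c2nc3c(ccc4ccccc43)c(-c3cc([N+](=O)[O-])ccc3N)c12` gives 93.1 ug/mL;
compound 3 `Cc1nc2c3ccccc3ccc2c2nc3c(ccc4ccccc43)c(-c3ccccc3)c12` gives 164 ug/mL.

The compounds share one core and differ only in the group carried on a single aromatic carbon of it. Compound 1 holds the second highest of the numbers, but the distances to the others are small: a 1.3-fold lower number from compound 1 to compound 2 (0.12 log units; within the scatter) and a 1.3-fold higher number from compound 1 to compound 3 (0.12 log units; within the scatter) both stay within the usual scatter of repeated measurements, so no order among the measured compounds can be claimed. The remaining step, a 1.8-fold higher number from compound 2 to compound 3 (0.25 log units; within the scatter), is likewise within the scatter.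

Compound 4 `Cc1nc2c3ccccc3ccc2c2nc3c(ccc4ccccc43)c(-c3cccc4ccccc34)c12` has not yet been measured. It differs from compound 1 in one place: naphthalen-1-yl in place of 4-methylphenyl on an aromatic carbon. This is the same kind of change already seen in the steps from compound 1 to compound 2 and from compound 1 to compound 3, where the group on that carbon was exchanged without moving the number beyond the scatter. For compound 4 the expected step is therefore a 1.0-fold lower number from compound 1 to compound 4 (0.01 log units; within the scatter), none of real size in either direction. Compound 4 is expected to give 120 ug/mL in this assay, with a range from 55 ug/mL to 260 ug/mL.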

Compound 4, half-maximal inhibitory concentration: 111 ug/mL
Estimate against measurement, compound 4: 1.1-fold (0.03 log units) above; the measured number falls inside the stated range.
By their numbers in this assay, from the lowest: compounds 2, 4, 1 and 3 (each within the scatter of the next).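

For the compounds shown here, on this aromatic carbon, opposite the ring nitrogen, the earlier compounds carried a single ring, and compound 4 is the first here to carry two fused rings: naphthalen-1-yl brings two six-membered aromatic rings of carbon only where 4-methylphenyl brought one, and in this assay the outcome is a 1.1-fold lower number from compound 1 to compound 4 (0.04 log units; within the scatter). The comparisons with the other two groups read the same way, with a 1.5-fold lower number from compound 3 to compound 4 (0.17 log units; within the scatter) for the exchange of phenyl and a 1.2-fold higher number from compound 2 to compound 4 (0.08 log units; within the scatter) for the exchange of 2-amino-5-nitrophenyl. Across these four compounds, then, enlarging the aromatic group on this carbon produces no step beyond the scatter, none of the four goes against that, and no order among them can be claimed.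

On these data alone, all four groups are aromatic rings joined directly to this carbon, so it remains open whether an amine, a carboxylic acid or a longer carbon chain in the same place would move the number beyond the scatter. Nothing in the available data accounts for how little the number shifts across these groups.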